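Shortening the Chain on a Weak Kinase Inhibitor

The source may report more compounds than this note shows. Statements on the series, on what has been measured and on what is new or still open speak of the compounds shown alone.

Three compounds have so far been measured in an assay on isolated protein for inhibition of deoxycytidine kinase (Rattus norvegicus); a higher number here means a weaker inhibitor, a lower number a stronger inhibitor:

Compound 1, `CCCCCCCCOc1nccc(N)n1`: 1000000 nM
Compound 2, `Nc1ccnc(Sc2ccc3ccccc3c2)n1`: 500000 nM
Compound 3, `Nc1ccnc(Oc2ccc(Cl)cc2)n1`: 5000000 nM

All three numbers are very high, so each compound is at best a feeble inhibitor. Among them compound 1 has the second highest number. Compound 2 lies closest to it, and the gap between the two falls within the usual scatter of such measurements, so they cannot be told apart. Compound 3 is furthest away, with a higher number that lies beyond the scatter, so compound 3 is the weaker inhibitor of those two.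

Compound 4, `CCCCCOc1nccc(N)n1`, has not yet been measured in this assay. It differs from compound 1 in one place: hydrogen in place of propyl on a saturated chain carbon, five bonds along the chain from an oxygen on an aromatic ring. In other words, the chain is shortened while the shared core stays the same.

For the measured compounds named here, no pair of measured compounds differs in this one place, so nothing on record shows how chain length alone moves the number in this assay. With compound 1 already a feeble inhibitor at 1000000 nM, little room remains for the number to rise, and all the measured compounds sit at similarly high values. The expected step is therefore a 2.0-fold higher number from compound 1 to compound 4 (0.30 log units; within the scatter), which means no change beyond the scatter, with a slight lean toward a higher number. Compound 4 is thus estimated to give 2000000 nM in this assay, with a likely range from 500000 nM to 10000000 nM.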

Compound 4, half-maximal inhibitory concentration: 7000000 nM
For compound 4 the middle estimate is 3.5-fold (0.54 log units) below the measured one, within the range that was stated.
By their numbers in this assay, from the lowest: compounds 2 and 1 (each within the scatter of the next); then compounds 3 and 4 (each within the scatter of the next).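

Replacing propyl with hydrogen on a saturated chain carbon, five bonds along the chain from an oxygen on an aromatic ring, gives a 7.0-fold higher number from compound 1 to compound 4 (0.85 log units; beyond the scatter) in this assay. For the compounds shown here, this is the first pair that isolates this position, and it shows that chain length alone can shift the number beyond the scatter, even among inhibitors this feeble: the shorter chain of compound 4 goes with the weaker inhibition, and the group that leaves is made only of carbon, with no ring, no hydrogen-bond donors or acceptors, and no net charge. No measurement on hand gives a reason for this rise.

A single pair gives two chain lengths and cannot show whether the number changes steadily with each carbon removed, or whether it would fall further with a longer chain than that of compound 1. Also open, going by these compounds, is how the same position would respond to a chain ending in an amine or a carboxylic acid, which would show whether carbon length or the chain's end matters more.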